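A Second Methoxy Group and Its Cost in Cytotoxicity

The source may hold more compounds than are shown below. What is called first, only, known or untested is meant among the compounds shown, and "the series" means these compounds.

Three related compounds have so far been run in a functional assay on HT-29 cells (Homo sapiens) for cytotoxicity, read by MTT assay, with a stated time of 3 days; a lower number here means a stronger inhibitor, a higher number a weaker inhibitor. Compound 1 `COc1ccccc1-c1ccccc1O` gives 2.7 ug/mL. Compound 3 `COc1ccc(-c2ccccc2O)c(OC)c1`, which carries one more methoxy group, gives 33.7 ug/mL; the step from compound 1 to compound 3 is a 12-fold higher number from compound 1 to compound 3 (1.10 log units; beyond the scatter), and the change behind it is methoxy in place of hydrogen on an aromatic carbon. Compound 2 `COc1ccc(-c2ccccc2)cc1` gives 45 ug/mL, the highest of the three numbers; how its core differs from that of compound 1 is not broken down here. Compound 4 `COc1ccc(-c2ccccc2)cc1OC` has not yet been measured in this assay, and it differs from compound 2 by methoxy in place of hydrogen on an aromatic carbon. Within the data shown here, this is the same kind of change as the one from compound 1 to compound 3, though the surroundings differ: in compound 3 the new group sits meta to a methoxy group and para to a group of 7 heavy atoms, whereas in compound 4 it sits ortho to a methoxy group and meta to a group of 6 heavy atoms. Because the earlier step was a 12-fold higher number from compound 1 to compound 3 (1.10 log units; beyond the scatter), a further rise in this assay is expected, with an estimated step of a 2.0-fold higher number from compound 2 to compound 4 (0.30 log units; within the scatter). Compound 4 is therefore expected to give about 90 ug/mL, likely between 40 ug/mL and 250 ug/mL.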

Compound 4, half-maximal inhibitory concentration: 41 ug/mL
For compound 4 the middle estimate is 2.2-fold (0.34 log units) above the measured one; measured number inside the range.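

In this assay, methoxy in place of hydrogen on an aromatic carbon gives a 1.1-fold lower number from compound 2 to compound 4 (0.04 log units; within the scatter), so compound 2 and compound 4 cannot be told apart. The same change therefore does not carry a single effect from one core to the other, since the large step seen on the core of compound 1 does not recur on the core of compound 2: the same change on two cores in this assay, a 12-fold higher number (1.10 log units; beyond the scatter) from compound 1 to compound 3 and a 1.1-fold lower number (0.04 log units; within the scatter) from compound 2 to compound 4, 14-fold (1.14 log units) apart, beyond the scatter of two such steps

This does not show why the two steps differ or that the core alone decides the outcome, for the new methoxy group has different surroundings in compound 3 and compound 4, and two pairs cannot separate core from place.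

The compounds shown leave open whether an amine or a carboxylic acid in place of the same hydrogen would give different steps on the two cores. They also leave open whether a longer chain, such as ethoxy or propoxy, would follow the step seen with methoxy on either core.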